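The compounds below may be only part of what the source reports. "The series", "measured", "known", "first", "only" and "open" are said of these compounds alone.

Compound 1, with the structure `Oc1ccc(-c2cc(-c3cccs3)nc(-c3ccccc3Cl)c2)cc1`, was examined in an assay on isolated protein for inhibition of DNA topoisomerase 1 (Homo sapiens), with a stated time of 30 min, tested at 100 uM (a higher number here means a stronger effect of the compound at the concentration tested, a lower number a weaker effect), and gave 2.2%. For the measured compounds named here, only one other compound has been measured alongside it: compound 2, with the structure `Oc1cccc(-c2cc(-c3cccs3)nc(-c3ccccc3Cl)c2)c1`, which in this assay gave 2.7%. Going by the values given here, the step of a number 0.5 percentage points higher from compound 1 to compound 2 (within the scatter) is the only measured step, and it exchanges the hydroxyphenyl group, not the thiophene; it offers no guide to the change examined here. Compound 1 stands as one of two numbers that sit within the scatter of each other, both close to the bottom of the read-out.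

The next compound is compound 3, with the structure `Oc1ccc(-c2cc(-c3ccsc3)nc(-c3ccccc3Cl)c2)cc1`. Its difference from compound 1 is thiophen-3-yl in place of thiophen-2-yl on an aromatic carbon. Among the compounds with values here, no measured step touches this change, so no step in this assay beyond the scatter is expected from it. For compound 3 the expected step is a number 0.8 percentage points higher from compound 1 to compound 3 (within the scatter). Compound 3 is therefore estimated at 3%, within a range from -6% to 14%.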

Compound 3, a percentage reported as inhibition, at one concentration (the size of the read-out at that concentration, not a potency): 4.1%
Beside the measured number, compound 3's estimate is 1.1 percentage points below it; low and high end bracket the measured number.
By their numbers in this assay, from the lowest: compounds 1, 2 and 3 (each within the scatter of the next).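

Exchanging thiophen-2-yl for thiophen-3-yl, on the aromatic carbon next to the ring nitrogen, gives in this assay a number 1.9 percentage points higher from compound 1 to compound 3 (within the scatter), so this position now has a measured step of its own. The two compounds have the same atoms joined differently, and the point at which the thiophene is attached makes no difference here that can be told from the scatter; like the earlier exchange of the hydroxyphenyl group, this step leaves the number close to the bottom of the read-out. Nothing available here offers an explanation for the result of this exchange.

On these data alone, whether any other group at this position, such as a furan, a pyridine or a chain ending in an amine, would give a number beyond the scatter remains open. Also open, as far as these compounds go, is whether the same thiophene exchange would read differently on a core in which the 2-chlorophenyl group gave way to another group, such as a plain phenyl or a carboxylic acid-bearing phenyl.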